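Azetidine ether series: propyl extension at aromatic substituent

This account rests on a few compounds, and the source may have more. Where it says the series, first, only, none or still open, it means among the compounds named here.

Measured compounds in an assay on brain for binding affinity to Neuronal acetylcholine receptor; alpha4/beta2 (Rattus norvegicus), read by radioligand binding; a lower number here means a stronger inhibitor, a higher number a weaker inhibitor:
compound 1 `FC(F)(F)c1cncc(OC[C@@H]2CCN2)c1` gives 0.49 nM
compound 2 `Nc1cncc(OC[C@@H]2CCN2)c1` gives 0.082 nM
compound 3 `Cc1cncc(OC[C@@H]2CCN2)c1` gives 0.047 nM

Compound 3 holds the lowest number of the three, yet its gap to compound 2 is within the scatter (a 1.7-fold lower number from compound 2 to compound 3 (0.24 log units; within the scatter)); only compound 1 sits clearly apart (a 10-fold lower number from compound 1 to compound 3 (1.02 log units; beyond the scatter), a 6.0-fold lower number from compound 1 to compound 2 (0.78 log units; beyond the scatter)).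

Compound 4 `CCCc1cncc(OC[C@@H]2CCN2)c1` differs from compound 3 by ethyl in place of hydrogen on a saturated chain carbon bound to an aromatic carbon. Within the data shown here, no measured step is a chain extension; all three steps swap the whole group on the aromatic carbon, so they show only that this position matters, not how a longer alkyl behaves. An estimate for compound 4 in this assay is therefore broad, centred near no change, with the step of a 2.1-fold higher number from compound 3 to compound 4 (0.33 log units; beyond the scatter) expected. Compound 4 is estimated at 0.1 nM, range 0.03 nM to 0.5 nM.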

Compound 4, inhibition constant: 0.039 nM
Compound 4: middle estimate off by 2.6-fold (0.41 log units), on the high side; the range from low to high includes it.
By their numbers in this assay, from the lowest: compounds 4, 3 and 2 (each within the scatter of the next, the first and the last beyond it); then compound 1.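

Going from methyl to propyl on this aromatic carbon leaves the number in this assay within the scatter (a 1.2-fold lower number from compound 3 to compound 4 (0.08 log units; within the scatter)), so the position accommodates a longer alkyl group without a measurable loss of affinity. Propyl also stands clear of amino (a 2.1-fold lower number from compound 2 to compound 4 (0.32 log units; beyond the scatter)) and of trifluoromethyl (a 13-fold lower number from compound 1 to compound 4 (1.10 log units; beyond the scatter)), whereas methyl stands clear only of trifluoromethyl. No available evidence accounts for these results.

Open, going by these compounds, is how far this extends: whether a longer chain such as hexyl, a branched group such as isopropyl, or a phenyl ring on this carbon keeps the number at this level.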